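The source may hold more compounds than are shown below. What is called first, only, known or untested is meant among the compounds shown, and "the series" means these compounds.

Compounds in this series:
- Compound 1 `COc1ccc(-n2cnnc2-c2cc(OC)c(OC)c(OC)c2)cc1`: 5620 nM
- Compound 2 `COc1cc(-c2nncn2-c2ccc(N(C)C)cc2)cc(OC)c1OC`: 2630 nM
- Compound 3 `COc1ccc(-n2cnnc2-c2cc(OC)c(OC)c(OC)c2)cc1O`: not yet measured

In a functional assay on NCI-H322M cells (Homo sapiens) for inhibition (a lower number here means a stronger inhibitor of growth, a higher number a weaker inhibitor of growth), compound 1 holds the higher of the two numbers, 5620 nM, which makes it the weaker growth inhibitor of the pair.

Compound 3 keeps the core of compound 1 and differs in one place: hydroxy in place of hydrogen on an aromatic carbon. This is hydroxy in place of hydrogen on an aromatic carbon, ortho to a methoxy group.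

For the measured compounds named here, only one measured step bears on this change: a 2.1-fold lower number from compound 1 to compound 2 (0.33 log units; beyond the scatter). It is modest and only an indirect guide, since it replaces the methoxy group rather than adding a hydroxy. It does show that a change on this ring can move the number beyond the scatter. Going by the values given here, no measured step adds a hydroxy, so the data do not fix the size of this one.

A lower number is expected, by a larger step than the measured one, with wide uncertainty. Expressed as a step, the estimate is a 19-fold lower number from compound 1 to compound 3 (1.27 log units; beyond the scatter). For compound 3 the estimated value is 300 nM, with an expected range of 30 nM to 3000 nM.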

Compound 3, concentration for 50% growth inhibition: 91200 nM
Compound 3: middle estimate off by 300-fold (2.48 log units), on the low side, outside the stated range (above it).
By their numbers in this assay, from the lowest: compound 2; then compound 1; then compound 3.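

In this assay, a single added hydroxy on an aromatic carbon, ortho to a methoxy group, gives a 16-fold higher number from compound 1 to compound 3 (1.21 log units; beyond the scatter) and so makes the compound a much weaker inhibitor of growth. For the compounds shown here, the only earlier change on this ring, a 2.1-fold lower number from compound 1 to compound 2 (0.33 log units; beyond the scatter), went the other way and was modest, so the two changes show that this ring can respond in either direction and that a substituent of just one heavy atom can produce a large step. Nothing available explains why this hydroxy weakens growth inhibition, so the result stands as an observation without a known cause.

The compounds shown leave open whether any new group on this carbon would weaken growth inhibition or whether the effect is specific to the hydroxy, and an amine or a fluorine atom in the same place would help separate those two possibilities. As far as these compounds go, it also remains open whether a hydroxy on another carbon of this ring, or one replacing the methoxy group itself, would produce a step of similar size.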